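The source may hold more compounds than are shown below. What is called first, only, known or untested is meant among the compounds shown, and "the series" means these compounds.

Measured compounds:
- compound 1, `Cn1cc(/C=N/NC(N)=S)c2ccccc21`: > 200000 nM, a limit of the assay
- compound 2, `CN(C)c1ccc(/C=N/N=C(/N)S)c2ccccc12`: > 200000 nM, a limit of the assay
- compound 3, `COc1ccc(/C=N/NC(N)=S)c2ccccc12`: 47000 nM

In a toxicity assay on THP-1 cells (Homo sapiens) for cytotoxicity, read by MTT assay, with a stated time of 72 h (a higher number here means that more compound is needed for the effect, a lower number that less compound is needed), compound 1 gives only a limit, > 200000 nM. Compound 2 likewise gives only a limit, > 200000 nM. Among the measured compounds shown here, compound 3 is the sole compound of the three that returns a number, 47000 nM, while the other two sit at the limit of > 200000 nM in this assay, at which 2 of the 3 values shown sit. For the measured compounds named here, no step between measured compounds can be stated, so the effect of the substitution pattern on the shared core is not characterised by these data.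

Compound 4, `COCOc1ccc(/C=N/NC(N)=S)c2ccccc12`, differs from compound 3 by methoxy in place of hydrogen on a saturated chain carbon bound to an oxygen on an aromatic ring. Going by the values given here, no measured pair covers a change of this kind, so the expectation rests on the structural change alone: a small, uncharged extension of the chain on the ring oxygen. The step expected is a 1.2-fold higher number from compound 3 to compound 4 (0.07 log units; within the scatter), within the usual scatter and with no direction preferred. Compound 4 is therefore estimated at 55000 nM, expected to fall between 18000 nM and 170000 nM. A limit rather than a number remains a real possibility for compound 4, given that two of the three measured compounds returned only a limit.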

Compound 4, half-maximal effective concentration: > 200000 nM
Compound 4 was reported as a limit; the forecaster's own chance of this, stated with the estimate: 25%; at least 3.6-fold (0.56 log units) between middle value and limit.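

Among the compounds shown here, the oxygen on the aromatic ring is the first place where a single change can be read: in this assay, going from methoxy to methoxymethoxy gives an at least 4.2-fold higher number from compound 3 to compound 4 (0.62 log units; beyond the scatter). Compound 4 gives > 200000 nM, a limit of the assay and not a number. The step therefore has a lower end only, and compound 3 remains the one compound here that returns a number: the limit of > 200000 nM in this assay, at which 3 of the 4 values shown sit.

Still open, on these data alone, is how far the number for compound 4 lies past the limit, and whether the step follows the added oxygen in the chain or the greater chain length as such. Also open, as far as these compounds go, is how a hydroxyl, an ethoxy group or a longer chain ending in an amine on that oxygen would read in this assay.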